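Swapping the Linker Oxygen for Carbon in Compound 4

The source may hold more compounds than are shown below. What is called first, only, known or untested is meant among the compounds shown, and "the series" means these compounds.

Measured so far:
Compound 1 `Cn1ncc2c(=O)n(-c3ccccc3)c(CNc3cccc(F)c3)nc21`: 1050 nM
Compound 2 `Cn1ncc2c(=O)n(-c3ccccc3)c(COc3cccc(F)c3)nc21`: 780 nM
Compound 3 `O=c1c2cncn2nc(SCc2cccc(F)c2)n1-c1ccccc1`: 500 nM

In an assay on isolated protein for inhibition of Retinaldehyde dehydrogenase 3 (Homo sapiens) (on this read-out higher numbers stand for weaker inhibition and lower numbers for stronger inhibition), compound 2 stands second highest of the three numbers. Compound 1 sits within the scatter of it, as the step of a 1.3-fold lower number from compound 1 to compound 2 (0.13 log units; within the scatter) shows, and the value of compound 3 also lies within the scatter of compound 2. Compound 4 `Cn1ncc2c(=O)n(-c3ccccc3)c(CCc3cccc(F)c3)nc21` differs from compound 2 by 3-fluorobenzyl in place of 3-fluorophenoxy on a saturated chain carbon bound to an aromatic carbon. For the measured compounds named here, the only step that bears on this is the one from compound 1 to compound 2, which also changed the group on that saturated chain carbon and stayed within the scatter. A step of similar size, within the scatter, is therefore expected for a 1.0-fold higher number from compound 2 to compound 4 (0.01 log units; within the scatter). Compound 4 is estimated at 800 nM, with a range from 300 nM to 2500 nM.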

Compound 4, half-maximal inhibitory concentration in the Retinaldehyde dehydrogenase 3 assay: 2500 nM
Estimate against measurement, compound 4: 3.1-fold (0.49 log units) below, and the stated range covers the measured number.
By their numbers in the Retinaldehyde dehydrogenase 3 assay, from the lowest: compounds 3, 2 and 1 (each within the scatter of the next, the first and the last beyond it); then compound 4.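

In the Retinaldehyde dehydrogenase 3 assay this position does respond to the change: 3-fluorobenzyl gives weaker inhibition than either 3-fluorophenoxy (a 3.2-fold higher number from compound 2 to compound 4 (0.51 log units; beyond the scatter)) or (3-fluorophenyl)amino (a 2.4-fold higher number from compound 1 to compound 4 (0.38 log units; beyond the scatter)). In a physicochemical assay for solubility, using the shake flask method, in phosphate buffer, with a stated time of 24 h, at pH 7.4 (a higher number here means a more soluble compound, a lower number a less soluble compound), compound 2 gives 194000 nM and compound 4 gives 126000 nM (that is, a 1.5-fold lower number from compound 2 to compound 4 (0.19 log units; within the scatter)), so the loss of inhibition comes with no solubility step beyond the scatter. No measured evidence here explains the weaker inhibition. Still open, on these data alone, is how an amide or a longer chain on this saturated chain carbon would read in both assays.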